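The source may hold more compounds than are shown below. What is called first, only, known or untested is meant among the compounds shown, and "the series" means these compounds.

Working notes on the series. In a functional assay on WI-38 VA13 cells (Homo sapiens) for cytotoxicity (a lower number here means that less compound is needed, a higher number that more compound is needed for the effect), compound 2 `CC(C)(C)C(=O)c1sc2nc(-c3cccs3)ccc2c1N` gives 0.57 ug/mL, the highest of the three numbers recorded so far. Compound 1 `COc1ccc(C(=O)c2sc3nc(-c4cccs4)ccc3c2N)c(OC)c1` gives 0.52 ug/mL in this assay, which lies within the scatter of compound 2. Compound 3 `Nc1c(C(=O)c2cccc([N+](=O)[O-])c2)sc2nc(-c3cccs3)ccc12` gives 0.15 ug/mL in this assay, a lower number than compound 2 by a margin beyond the scatter; the two values simply show that less of compound 3 is needed than of compound 2. Compound 4 `Nc1c(C(=O)c2ccc(F)cc2F)sc2nc(-c3cccs3)ccc12` has not yet been measured. It differs from compound 2 by 2,4-difluorophenyl in place of tert-butyl on a carbonyl carbon. Among the measured compounds shown here, no step between two measured compounds matches this change. The measured values show that compound 1 and compound 3, both carrying a six-membered aromatic ring on the carbonyl, give numbers equal to or lower than compound 2. Compound 4 is therefore expected to give a modest step towards lower numbers, a 1.9-fold lower number from compound 2 to compound 4 (0.28 log units; within the scatter), though a result within the scatter of compound 2 would not be surprising. The estimate for compound 4 in this assay is 0.3 ug/mL, with a range from 0.1 ug/mL to 0.9 ug/mL.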

Compound 4, half-maximal effective concentration: 2.3 ug/mL
The estimate for compound 4 lay 7.7-fold (0.88 log units) below the measured number; the whole stated range lies below it.
By their numbers in this assay, from the lowest: compound 3; then compounds 1 and 2 (each within the scatter of the next); then compound 4.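

In this assay, 2,4-difluorophenyl in place of tert-butyl on a carbonyl carbon gives a 4.0-fold higher number from compound 2 to compound 4 (0.61 log units; beyond the scatter), so a six-membered aromatic ring at this place does not by itself lead to a lower number. Compound 1 gives 0.52 ug/mL, compound 3 gives 0.15 ug/mL and compound 4 gives 2.3 ug/mL, all with an aromatic ring on the carbonyl, so the number at this place depends on what that ring carries and not only on the ring being there. Nothing at hand bears on why the number rises with this change.

The compounds shown leave open whether a ring with a single fluorine, or with an amine or a carboxylic acid, would fall nearer compound 3 or compound 4. They also leave open how a longer chain in place of tert-butyl would compare with compound 2.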